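The source may hold more compounds than are shown below. What is called first, only, known or untested is meant among the compounds shown, and "the series" means these compounds.

Three compounds share one core and differ only in the amine that ends a chain attached through an oxygen to the aromatic part. Compound 1 `CCN1CCN(CCCOc2cc3nccc(Oc4c(F)cc(NC(=O)NN5C(=O)CSC5c5c(F)cccc5F)cc4F)c3cc2OC)CC1` carries an ethylpiperazine there; in a functional assay on MDA-MB-231 cells (Homo sapiens) for antiproliferative activity, read by MTT assay, with a stated time of 72 h (a higher number here means a weaker inhibitor, a lower number a stronger inhibitor), compound 1 gives 3100 nM. Compound 2 `COc1cc2c(Oc3c(F)cc(NC(=O)NN4C(=O)CSC4c4c(F)cccc4F)cc3F)ccnc2cc1OCCCN1CCc2sccc2C1` has a fused thiophene-containing bicyclic amine, and compound 3 `COc1cc2c(Oc3c(F)cc(NC(=O)NN4C(=O)CSC4c4c(F)cccc4F)cc3F)ccnc2cc1OCCCN1C[C@H]2CCCC[C@H]2C1` a bicyclic amine with two defined stereocentres. In this assay, among the compounds with values here, compound 2 gives "not determined" (no result reported), and in this assay compound 3 gives "not determined" (no result reported), so the only measured value in this set belongs to compound 1.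

Compound 4 `COc1cc2c(Oc3c(F)cc(NC(=O)NN4C(=O)CSC4c4c(F)cccc4F)cc3F)ccnc2cc1OCCCN1CCC(N2CCCCC2)CC1` differs from compound 3 in one place: a group of 12 heavy atoms (10 carbon, 2 nitrogen; 2 six-membered non-aromatic rings with 1 hetero atom each) in place of a group of 9 heavy atoms (8 carbon, 1 nitrogen; one five-membered non-aromatic ring with 1 hetero atom, one six-membered non-aromatic ring of carbon only), on a saturated chain carbon, three bonds along the chain from an oxygen on an aromatic ring, that is, a 4-(piperidin-1-yl)piperidin-1-yl group enters on the saturated chain carbon three bonds along the chain from the oxygen on the aromatic ring. Within the data shown here, compound 3 has no number, so no step can be calculated; the expectation for compound 4 rests instead on compound 1, which gives 3100 nM and shares the same core while differing only in the terminal amine. Compound 4 is therefore estimated at 2500 nM, with a range from 700 nM to 9000 nM.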

Compound 4, half-maximal inhibitory concentration: 5380 nM
For compound 4 the middle estimate is 2.2-fold (0.33 log units) below the measured one; the measured number falls inside the stated range.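

In this assay, putting 4-(piperidin-1-yl)piperidin-1-yl in place of 4-ethylpiperazin-1-yl on a saturated chain carbon, three bonds along the chain from an oxygen on an aromatic ring, gives a 1.7-fold higher number from compound 1 to compound 4 (0.24 log units; within the scatter) and so this exchange of terminal amines shows no real difference in antiproliferative activity. Within the data shown here, this is the first comparison available at this position, while steps involving compound 2 or compound 3 cannot be read without numbers for those compounds. No measurement is available that could explain this result.

From the compounds shown here alone, it remains open whether a morpholine or a simple dimethylamino group at the end of the chain would give a value beyond the scatter. A longer chain carrying either of the two measured amines also remains untested in the compounds shown here.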